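Phenyl in place of (tert-butoxy)methyl in compound 1

The source may hold more compounds than are shown below. What is called first, only, known or untested is meant among the compounds shown, and "the series" means these compounds.

Measured so far in a functional assay on a cell-free system (plasma, Homo sapiens), with a stated time of 3 min; a higher number here means a weaker inhibitor, a lower number a stronger inhibitor
compound 1 `CC(C)(C)OC[C@@H](O)C(=O)N1[C@H](C(=O)NCc2cc(Cl)ccc2-n2cnnn2)C[C@@H]2C[C@@H]21` gives 500 nM
compound 2 `CC1(C[C@@H](O)C(=O)N2N=CC[C@H]2C(=O)NCc2cc(Cl)ccc2-n2cnnn2)CC1` gives 730 nM
compound 3 `CC(C)(C)[C@@H](O)C(=O)N1OCC[C@H]1C(=O)NCc1cc(Cl)ccc1-n1cnnn1` gives 1600 nM

Compound 1 and compound 2 lie within the scatter of each other, while compound 3 has a higher number than compound 1, beyond the scatter. Compound 4 `O=C(NCc1cc(Cl)ccc1-n1cnnn1)[C@@H]1C[C@@H]2C[C@@H]2N1C(=O)[C@H](O)c1ccccc1` has not yet been measured. Its difference from compound 1 is phenyl in place of (tert-butoxy)methyl on a saturated chain carbon bound to a carbonyl carbon and an oxygen on a saturated carbon and it puts phenyl in place of (tert-butoxy)methyl on a saturated chain carbon bound to a carbonyl carbon and an oxygen on a saturated carbon. Within the data shown here, no two measured compounds differ in one place alone, and none carries phenyl there, so the expectation is loose. It starts from compound 1 at 500 nM and allows for a rise towards compound 3 at 1600 nM in this assay as the measured spread. A modest move towards a weaker inhibitor is expected, with the estimated step of a 2.2-fold higher number from compound 1 to compound 4 (0.34 log units; beyond the scatter) as its size. Compound 4 is expected at 1100 nM (350 nM to 3500 nM).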

Compound 4, half-maximal inhibitory concentration: 620 nM
Compound 4: the middle estimate sits 1.8-fold (0.25 log units) above what was measured; low and high end bracket the measured number.
By their numbers in this assay, from the lowest: compounds 1, 4 and 2 (each within the scatter of the next); then compound 3.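

In this assay, among these compounds, the first one-place comparison in this set gives a 1.2-fold higher number from compound 1 to compound 4 (0.09 log units; within the scatter), so exchanging (tert-butoxy)methyl for phenyl on the saturated chain carbon bound to a carbonyl carbon and an oxygen leaves the two compounds indistinguishable. At this place, on the core of compound 1, an open chain carrying one hydrogen-bond acceptor and a six-membered aromatic ring of carbon only, each of 6 heavy atoms, give readings that cannot be told apart. Nothing available explains why the two groups read alike.

Going by these compounds, it remains open whether an amine, a carboxylic acid or a longer chain would be accepted at this place in the same way. On these data alone, it is also open whether phenyl would read alike on the cores of compound 2 and compound 3.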